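A few compounds are considered here, and "the series" means these few. Any claim that something is new, unique, unknown or untested is made for them only; others in the source may bear on it.

Measured compounds:
compound 1 `CC(C(=O)NCc1ccc(C(F)(F)F)nc1Br)c1ccc(NS(C)(=O)=O)c(F)c1`, 169 nM in an assay on CHO cells for antagonist activity at transient receptor potential cation channel subfamily V member 1 (Homo sapiens), read by FLIPR and calcium flux; on this read-out lower numbers stand for stronger inhibition and higher numbers for weaker inhibition
compound 2 `CCC1CC=C(c2nc(C(F)(F)F)ccc2CNC(=O)C(C)c2ccc(NS(C)(=O)=O)c(F)c2)CC1`, 0.1 nM

Going by the values given here, of the two numbers known in this assay, compound 2 holds the lower one. Among the compounds with values here, the only recorded step, a 1700-fold lower number from compound 1 to compound 2 (3.23 log units; beyond the scatter), shows how much the group on that aromatic carbon governs the read-out, since the exchange of bromo for 4-ethylcyclohex-1-en-1-yl brought the number down by a large amount that lies well beyond the scatter.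

Compound 3 `CC(C(=O)NCc1ccc(C(F)(F)F)nc1C1=CCC(C)(C)CC1)c1ccc(NS(C)(=O)=O)c(F)c1` keeps that six-membered non-aromatic ring but is built from the same atoms joined differently: 4,4-dimethylcyclohex-1-en-1-yl in place of 4-ethylcyclohex-1-en-1-yl on an aromatic carbon. Within the data shown here, the step from compound 1 to compound 2 bears on this only indirectly, as it concerns the presence of the ring rather than where its carbons sit; no measured pair shows what moving the substituents on the ring does. Because compound 2 already gives 0.1 nM, a further large drop seems unlikely, and the expectation is a small step of a 3.0-fold higher number from compound 2 to compound 3 (0.48 log units; beyond the scatter), probably within the scatter or slightly toward a higher number. Compound 3 is therefore expected to give about 0.3 nM, in the range 0.05 nM to 2 nM.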

Compound 3, inhibition constant: 0.2 nM
Compound 3: middle estimate off by 1.5-fold (0.18 log units), on the high side; low and high end bracket the measured number.
By their numbers in this assay, from the lowest: compounds 2 and 3 (each within the scatter of the next); then compound 1.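

Exchanging 4-ethylcyclohex-1-en-1-yl for 4,4-dimethylcyclohex-1-en-1-yl on the aromatic carbon next to the ring nitrogen gives in this assay only a 2.0-fold higher number from compound 2 to compound 3 (0.30 log units; within the scatter) and so places compound 2 and compound 3 level, which shows that this position tolerates a rearrangement of the ring's carbons without a change that can be read. The exchange of bromo for the new group gives an 850-fold lower number from compound 1 to compound 3 (2.93 log units; beyond the scatter) and is the second large step recorded at this position, so the drop is not confined to the single 4-ethyl arrangement: both substituted cyclohexenyl groups stand far from bromo, and no compound shown goes against this. Nothing available explains either result.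

The compounds shown leave open whether the ring's double bond matters, as a saturated cyclohexyl group or a phenyl ring at this position could show, and whether a ring is needed at all rather than an open chain such as n-butyl. They also leave open how a morpholine ring, an amine or a hydroxyl group on the cyclohexenyl ring would fare here.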